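Swapping Methoxyphenyl for Dichlorophenyl on the Thiourea Nitrogen

The compounds below may be only part of what the source reports. "The series", "measured", "known", "first", "only" and "open" are said of these compounds alone.

Compound 2 `CNC(=O)c1ccc(Oc2cccc(NC(=S)Nc3ccc(OC)cc3)c2)nc1` gives in a functional assay on PC-3 cells (Homo sapiens) for antiproliferative activity, read by MTT assay (a lower number here means a stronger inhibitor, a higher number a weaker inhibitor), only a limit, > 100000 nM. Compound 1 `CNC(=O)c1ccc(Oc2cccc(NC(=S)Nc3ccc(F)c(F)c3)c2)nc1` gives 23100 nM in this assay. The step of an at least 4.3-fold higher number from compound 1 to compound 2 (0.63 log units; beyond the scatter) shows the methoxy compound is weaker, and its size cannot be fixed more closely since compound 2 sits at the limit of > 100000 nM in this assay, at which 1 of the 2 values shown sits. Compound 3 `CNC(=O)c1ccc(Oc2cccc(NC(=S)Nc3ccc(Cl)cc3Cl)c2)nc1` brings (2,4-dichlorophenyl in place of 4-methoxyphenyl on an amide-type nitrogen). Compound 1 with its difluorophenyl gave a measurable number, 23100 nM, so a halogenated ring is expected to recover some potency. For compound 3 a step of about an at least 6.6-fold lower number from compound 2 to compound 3 (0.82 log units; beyond the scatter) is expected. Compound 3 is estimated at 15000 nM, within a range from 4000 nM to 60000 nM.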

Compound 3, half-maximal inhibitory concentration: 19300 nM
Compound 3: middle estimate off by 1.3-fold (0.11 log units), on the low side; low and high end bracket the measured number.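

The change to 2,4-dichlorophenyl on this thiourea nitrogen gives an at least 5.1-fold lower number from compound 2 to compound 3 (0.71 log units; beyond the scatter), so the loss seen with 4-methoxyphenyl is not shared by every substituted phenyl ring here. That step gives only a minimum size: the limit of > 100000 nM in this assay, at which 1 of the 3 values shown sits.

In this assay, the two halogenated rings show a 1.2-fold lower number from compound 1 to compound 3 (0.08 log units; within the scatter), so this change of halogen and its places on the ring leaves the number within the scatter.

As far as these compounds go, it remains open whether the halogens matter or only the absence of methoxy, a question a plain phenyl ring on this nitrogen could address. From the compounds shown here alone, how a trifluoromethyl or nitrile group would behave here also remains open.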